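Methyl to Methoxy: Expected Microsomal Half-Life of Compound 4

The source may hold more compounds than are shown below. What is called first, only, known or untested is meant among the compounds shown, and "the series" means these compounds.

Compound 1 `CCC(CC)Nc1nc(OC)c(-c2ccc(Cl)cc2Cl)nc1C`: 0.933 h
Compound 2 `CCc1nc(-c2ccc(Cl)cc2Cl)c(CC)nc1NC(CC)CC`: 0.283 h
Compound 3 `CCc1nc(NC(CC)CC)c(F)nc1-c1ccc(Cl)cc1Cl`: 1.22 h

In an in vitro ADME assay on microsomes (Homo sapiens) for metabolic stability (a higher number here means that the compound lasts longer, a lower number that the compound disappears faster), compound 1 stands second highest of the three numbers. Compound 3 lies within the scatter of compound 1, while compound 2 sits lower by an amount beyond the scatter. Compound 4 `CCC(CC)Nc1nc(OC)c(-c2ccc(Cl)cc2Cl)nc1OC` differs from compound 1 in one place: methoxy in place of methyl on an aromatic carbon. Going by the values given here, the only measured step, a 4.3-fold higher number from compound 2 to compound 3 (0.63 log units; beyond the scatter), concerns a different change and so gives no direct guide to this one. With nothing in the data pointing either way, the step expected in this assay is a 1.0-fold lower number from compound 1 to compound 4 (0.02 log units; within the scatter), which stays within the scatter. Compound 4 is therefore estimated at 0.9 h, with a range from 0.4 h to 2 h.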

Compound 4, half-life: 0.267 h
Compound 4: middle estimate off by 3.4-fold (0.53 log units), on the high side, and the stated range ends above it.
By their numbers in this assay, from the lowest: compounds 4 and 2 (each within the scatter of the next); then compounds 1 and 3 (each within the scatter of the next).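

At this position, next to the ring nitrogen and para to a methoxy group, swapping one small group for another is not a neutral change. In this assay, methoxy in place of methyl gives a 3.5-fold lower number from compound 1 to compound 4 (0.54 log units; beyond the scatter), a step beyond the usual scatter, so this position matters for how long the compound lasts. No measurement shown explains the fall.

Still open, as far as these compounds go, is whether an ethoxy group, a nitrile or a longer chain at this position would behave like methyl or like methoxy. Also open, from the compounds shown here alone, is whether the same swap would give a similar step on a different core.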